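A few compounds are considered here, and "the series" means these few. Any claim that something is new, unique, unknown or untested is made for them only; others in the source may bear on it.

Working notes on the series. Compound 3 `COc1cc(/C=N/Nc2nc(-c3ccc(F)c(F)c3)cs2)c(Br)c(Br)c1OC` gives 19600 nM in a functional assay on U-87MG ATCC cells for inhibition, with U-87 MG (Homo sapiens) as the target, read by MTT assay, with a stated time of 48 h (a lower number here means a stronger inhibitor, a higher number a weaker inhibitor), and holds the lowest number among the measured values; compound 2 `COc1cc(/C=N/Nc2nc(-c3ccc(F)c(F)c3)cs2)cc(Br)c1OC` sits nearest at 26300 nM, the difference being a 1.3-fold lower number from compound 2 to compound 3 (0.13 log units; within the scatter). Compound 1 `COc1cc(/C=N/Nc2nc(-c3ccc(C(F)(F)F)cc3)cs2)c(Br)c(Br)c1OC` reaches only a limit, > 100000 nM, as stated in the limit of > 100000 nM in this assay, at which 1 of the 3 values shown sits. The step to compound 4 `COc1cc(/C=N/Nc2nc(-c3ccccc3)cs2)c(Br)c(Br)c1OC` is phenyl in place of 3,4-difluorophenyl on an aromatic carbon. Within the data shown here, the only measured step that touches the aryl group is an at least 5.1-fold lower number from compound 1 to compound 3 (0.70 log units; beyond the scatter), so changes on this ring have moved the number by a sizable amount in one case. Removing both fluorines is expected to shift the number modestly toward weaker inhibition, a 1.8-fold higher number from compound 3 to compound 4 (0.25 log units; within the scatter). Compound 4 is estimated at 35000 nM, with a range from 12000 nM to 100000 nM.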

Compound 4, half-maximal inhibitory concentration: 20100 nM
For compound 4 the middle estimate is 1.7-fold (0.24 log units) above the measured one, and the stated range covers the measured number.
By their numbers in this assay, from the lowest: compounds 3, 4 and 2 (each within the scatter of the next). At a limit, above all of these: compound 1.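

On this aromatic carbon, phenyl and 3,4-difluorophenyl cannot be told apart: a 1.0-fold higher number from compound 3 to compound 4 (0.01 log units; within the scatter). The two fluorines therefore make no readable difference here, whereas hydrogen in place of trifluoromethyl gives an at least 4.9-fold lower number from compound 1 to compound 4 (0.69 log units; beyond the scatter). That step has no upper bound, as compound 1 is a limit and not a number: the limit of > 100000 nM in this assay, at which 1 of the 4 values shown sits.

On these data alone, whether an amine or a carboxylic acid on this phenyl would move the number stays open. So does the true size of the gap to compound 1.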